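Replacing the pyrazolyl amide substituent with a hydroxyethyl chain

The source may hold more compounds than are shown below. What is called first, only, known or untested is meant among the compounds shown, and "the series" means these compounds.

Compound 3 `Cc1ccc(OCC(=O)N(Cc2cccs2)c2c(C)n[nH]c2C)cc1` gives 0.3 nM in an assay on HEK293 cells for agonist activity at transient receptor potential cation channel subfamily M member 8 (Homo sapiens), read by fluorescence and calcium flux, with a stated time of 15 min (a higher number here means that more compound is needed for the effect, a lower number that less compound is needed), the lowest number among the three measured compounds; compound 1 `Cc1ccc(OCC(=O)N(Cc2cccs2)c2cccnc2)cc1` gives 198 nM and compound 2 `Cc1ccc(OCC(=O)N(Cc2cccs2)C(C)(C)C)cc1` gives 11000 nM. Compound 4 `Cc1ccc(OCC(=O)N(CCO)Cc2cccs2)cc1` differs from compound 3 by 2-hydroxyethyl in place of 3,5-dimethyl-1H-pyrazol-4-yl on an amide-type nitrogen. Among the compounds with values here, the steps that bear on this change are a 37000-fold lower number from compound 2 to compound 3 (4.56 log units; beyond the scatter) and a 660-fold lower number from compound 1 to compound 3 (2.82 log units; beyond the scatter), both large; the step of a 56-fold higher number from compound 1 to compound 2 (1.74 log units; beyond the scatter) further shows that the substituent with no ring on this nitrogen sits far above the ring-bearing ones. A large rise in the number is therefore expected for compound 4, a 17000-fold higher number from compound 3 to compound 4 (4.22 log units; beyond the scatter). Compound 4 is estimated to give 5000 nM in this assay, with a range from 500 nM to 50000 nM.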

Compound 4, half-maximal effective concentration: 900 nM
For compound 4 the middle estimate is 5.6-fold (0.74 log units) above the measured one; the measured number falls inside the stated range.
By their numbers in this assay, from the lowest: compound 3; then compound 1; then compound 4; then compound 2.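

Lack of a ring on the amide-type nitrogen does not by itself set the number: 2-hydroxyethyl in place of tert-butyl gives a 12-fold lower number from compound 2 to compound 4 (1.09 log units; beyond the scatter) in this assay, and 2-hydroxyethyl in place of pyridin-3-yl gives only a 4.5-fold higher number from compound 1 to compound 4 (0.66 log units; beyond the scatter). The step to 3,5-dimethyl-1H-pyrazol-4-yl stays far larger, a 3000-fold higher number from compound 3 to compound 4 (3.48 log units; beyond the scatter), although both groups count the same hydrogen-bond donors and acceptors. No available evidence accounts for these differences.

Open, as far as these compounds go, is how a longer chain such as 3-hydroxypropyl or a 2-aminoethyl chain would compare with 2-hydroxyethyl. Also open, from the compounds shown here alone, is whether a carboxylic acid on this nitrogen would fall nearer compound 3 or compound 2.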